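Series notes: aryl group on the pyrrole nitrogen

A few compounds are considered here, and "the series" means these few. Any claim that something is new, unique, unknown or untested is made for them only; others in the source may bear on it.

For the measured compounds named here, in an ADME assay on L6 cells (Rattus norvegicus) for cytotoxicity, read by resazurin assay, with a stated time of 72 h (a higher number here means that more compound is needed for the effect, a lower number that less compound is needed), two compounds of the shared core have numbers so far. Compound 1 `CCOC(=O)C1=C(C)N/C(=C/c2cc(C)n(-c3ccc([S+](C)[O-])cc3)c2C)C1=O` gives 220000 nM. Compound 2 `CCOC(=O)C1=C(C)N/C(=C/c2cc(C)n(-c3ccc(SC)cc3)c2C)C1=O` gives 54000 nM. Compound 2 stands as the lowest of the two numbers; the step of a 4.1-fold lower number from compound 1 to compound 2 (0.61 log units; beyond the scatter) separates it from compound 1, so less compound 2 is needed than compound 1 in this assay.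

Compound 3 `CCOC(=O)C1=C(C)N/C(=C/c2cc(C)n(-c3cccnc3)c2C)C1=O` is not yet measured. It differs from compound 2 by pyridin-3-yl in place of 4-(methylsulfanyl)phenyl on an aromatic nitrogen. Going by the values given here, the only measured step, from compound 1 to compound 2, changes a substituent on the same aryl group that is now exchanged as a whole; it shows that this part of the molecule can move the number beyond the scatter, but it does not tell the direction for a ring exchange. For compound 3 a modest rise of the number back toward the region of compound 1 is expected, a 2.0-fold higher number from compound 2 to compound 3 (0.31 log units; beyond the scatter), with a wide range. The estimate for compound 3 in this assay is 110000 nM, between 40000 nM and 300000 nM.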

Compound 3, half-maximal effective concentration: 160000 nM
Compound 3: the middle estimate sits 1.5-fold (0.16 log units) below what was measured; the measured number falls inside the stated range.
By their numbers in this assay, from the lowest: compound 2; then compounds 3 and 1 (each within the scatter of the next).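

Exchanging the whole aryl group on the aromatic nitrogen moves the number beyond the scatter in this assay (a 3.0-fold higher number from compound 2 to compound 3 (0.47 log units; beyond the scatter)), so this place responds to a ring exchange as well as to a change in the substituent on the phenyl ring. Compound 2, with 4-(methylsulfanyl)phenyl, now has the lowest number, and its steps to the other two compounds are both printed as beyond the scatter. Pyridin-3-yl and the aryl group of compound 1 cannot be told apart in this assay (a 1.4-fold lower number from compound 1 to compound 3 (0.14 log units; within the scatter)), and no measurement at hand accounts for any of these differences.

Open, as far as these compounds go, is whether the lower number of compound 2 goes with the methylsulfanyl group or with the carbon-only ring, a question that a plain phenyl group on the same nitrogen would bear on. Also open, from the compounds shown here alone, is where an amine or a carboxylic acid on the aryl group would fall relative to the three numbers now in hand.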